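This account rests on a few compounds, and the source may have more. Where it says the series, first, only, none or still open, it means among the compounds named here.

Measured compounds:
compound 1 `CC(C)Oc1ccc(NC(=O)CSc2nnc(Cc3nn(C)c(=O)c4ccccc34)n2C)cc1`, > 30000 nM (a limit of the assay)
compound 2 `Cn1c(Cc2nn(C)c(=O)c3ccccc23)nnc1SCCCCCCCC(=O)Nc1ccc(O)cc1O`, 17000 nM
compound 3 `Cn1c(Cc2nn(C)c(=O)c3ccccc23)nnc1SCC(=O)Nc1ccc(O)cc1`, "not active" (no number reported)

Going by the values given here, in an assay on isolated protein (Mus musculus) for inhibition of IL15-IL15 receptor (Homo sapiens), read by resazurin assay, with stated times of 30 min and 2.5 days (a lower number here means a stronger inhibitor, a higher number a weaker inhibitor), compound 2 gives 17000 nM, the only number reported among the three. Compound 1 reaches only a limit of this assay, > 30000 nM. Compound 3 is described as "not active" (no number reported) with no number given. Among the compounds with values here, with two of three entries falling under the limit of > 30000 nM in this assay, at which 1 of the 3 values shown sits, or outside any number, no step between measured compounds can be quoted.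

Compound 4 `Cn1c(Cc2nn(C)c(=O)c3ccccc23)nnc1SCCCCCCCC(=O)Nc1ccc(O)cc1` differs from compound 2 by hydrogen in place of hydroxy on an aromatic carbon. The expected step from compound 2 to compound 4 is a 2.1-fold higher number from compound 2 to compound 4 (0.31 log units; beyond the scatter), in the weaker direction, since compound 3, which also carries the 4-hydroxyphenyl group, reports "not active" (no number reported). Compound 4 is therefore estimated at 35000 nM, within 12000 nM to 100000 nM.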

Compound 4, half-maximal inhibitory concentration: > 30000 nM
Compound 4 gave a limit, no number; the forecaster's own chance of this, stated with the estimate: 60%; the middle value does not contradict the limit.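

Going by these compounds alone, replacing 2,4-dihydroxyphenyl with 4-hydroxyphenyl gives the first single-place comparison in this set: in this assay, the change yields an at least 1.7-fold higher number from compound 2 to compound 4 (0.24 log units; that floor lies within the scatter). The hydroxy at this position may therefore matter, but the printed floor does not establish this beyond the scatter. Compound 4 gives only a limit of the assay, so the full size of the step cannot be read: the limit of > 30000 nM in this assay, at which 2 of the 4 values shown sit.

The compounds shown leave open whether an amine or a carboxylic acid in place of this hydroxy would keep the value of compound 2. They also leave open whether a longer chain would change it.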